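A few compounds are considered here, and "the series" means these few. Any claim that something is new, unique, unknown or untested is made for them only; others in the source may bear on it.

Among the measured compounds shown here, in a functional assay on SK-BR-3 cells (Homo sapiens) for cytotoxicity, read by fluorescence and resazurin assay, with a stated time of 72 h (a lower number here means a stronger inhibitor, a higher number a weaker inhibitor), compound 2 `Nc1nc(Nc2ccc(S(N)(=O)=O)cc2)sc1C(=O)c1cccc(F)c1` gives 1200 nM, the higher of the two true numbers so far. Its nearest neighbour, compound 1 `Nc1nc(Nc2ccc(S(N)(=O)=O)cc2)sc1C(=O)c1ccccc1[N+](=O)[O-]`, gives 490 nM. Compound 3 `Nc1nc(Nc2ccc(S(N)(=O)=O)cc2)sc1C(=O)c1ccc(S(N)(=O)=O)cc1` is reported as > 10000 nM, which is a limit of the assay and not a number.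

The next compound to be measured is compound 4 `Nc1cccc(C(=O)c2sc(Nc3ccc(S(N)(=O)=O)cc3)nc2N)c1`, which has amino in place of fluoro on an aromatic carbon, turning 3-fluorophenyl into 3-aminophenyl: amino in place of fluoro on an aromatic carbon. For the measured compounds named here, no measured step makes this exact change. The closest evidence is a change of the aryl group on the same carbonyl carbon, 3-fluorophenyl in place of 2-nitrophenyl, which gave a 2.4-fold higher number from compound 1 to compound 2 (0.39 log units; beyond the scatter), a modest step. Going by the values given here, with only that step as a guide, a change of similar modest size or smaller is expected in this assay, and no direction can be favoured. The expected change is a 1.2-fold lower number from compound 2 to compound 4 (0.08 log units; within the scatter), which would not be a firm shift. The estimate for compound 4 is 1000 nM, with an expected range from 300 nM to 3500 nM.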

Compound 4, half-maximal inhibitory concentration: 4100 nM
Compound 4: the middle estimate sits 4.1-fold (0.61 log units) below what was measured; measured number outside the range, above it.
By their numbers in this assay, from the lowest: compound 1; then compound 2; then compound 4. At a limit, above all of these: compound 3.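

In this assay, amino in place of fluoro on an aromatic carbon, meta to a large group, is the first change shown that alters only the substituent at this place, and the step is beyond the scatter: a 3.4-fold higher number from compound 2 to compound 4 (0.53 log units; beyond the scatter) in a modest rise. Measured against the 2-nitrophenyl group, the 3-aminophenyl group gives a larger step, an 8.4-fold higher number from compound 1 to compound 4 (0.92 log units; beyond the scatter), so the order among the three true numbers is now set by steps that all lie beyond the scatter. Nothing measured here gives a cause for this rise.

The compounds shown leave open whether the rise is specific to the amino group, since a hydroxyl, a methoxy or an acetylated amine at the same place would test this. As far as these compounds go, whether the same swap behaves alike elsewhere on the ring also stays open.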